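Urea aryl swap on the pyrazole series: compound 3 outlook

The source may hold more compounds than are shown below. What is called first, only, known or untested is meant among the compounds shown, and "the series" means these compounds.

Two compounds are in hand. Compound 1 `O=C(Nc1cccc(-n2cc(-c3ccncc3)c(-c3ccc(Cl)c(O)c3)n2)c1)Nc1cccc(C(F)(F)F)c1` gives 1640 nM in a functional assay on IGROV-1 cells (Homo sapiens) for inhibition, read by sulforhodamine B assay, with a stated time of 48 h; a higher number here means a weaker inhibitor of growth, a lower number a stronger inhibitor of growth; compound 2 `COc1cc(-c2nn(-c3cccc(NC(=O)Nc4ccc(Cl)c(Cl)c4)c3)cc2-c2ccncc2)ccc1Cl` gives 1180 nM, and the two sit within the usual scatter of each other, so compound 2 is not set apart by the numbers shown. Compound 3 `COc1cc(-c2nn(-c3cccc(NC(=O)Nc4cccc(C(F)(F)F)c4)c3)cc2-c2ccncc2)ccc1Cl` differs from compound 2 by 3-(trifluoromethyl)phenyl in place of 3,4-dichlorophenyl on an amide-type nitrogen. Going by the values given here, no measured pair shows this change. For compound 3 the expected step is a 1.1-fold higher number from compound 2 to compound 3 (0.04 log units; within the scatter), none beyond the scatter. Compound 3 is therefore estimated at 1300 nM, with a range from 600 nM to 2900 nM.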

Compound 3, concentration for 50% growth inhibition: 1060 nM
Estimate against measurement, compound 3: 1.2-fold (0.09 log units) above, within the range that was stated.
By their numbers in this assay, from the lowest: compounds 3, 2 and 1 (each within the scatter of the next).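

Two single-place comparisons now exist in this assay. On the amide-type nitrogen, 3-(trifluoromethyl)phenyl in place of 3,4-dichlorophenyl gives a 1.1-fold lower number from compound 2 to compound 3 (0.05 log units; within the scatter) and on the oxygen on the aromatic ring, methyl in place of hydrogen gives a 1.5-fold lower number from compound 1 to compound 3 (0.19 log units; within the scatter) and so neither change separates its pair at either position. From the compounds shown here alone, whether an amine or a carboxylic acid on that aryl group, or a longer chain on the oxygen, would give a step beyond the scatter remains open. No supporting data bear on these results.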